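This account rests on a few compounds, and the source may have more. Where it says the series, first, only, none or still open, it means among the compounds named here.

In a functional assay on CHO cells with adenosine receptor A1 (Homo sapiens) as the target, read by cAMP accumulation and immunoassay, with a stated time of 6 min, tested at 0.1 uM (a lower number here means a stronger effect, a higher number a weaker effect of the compound at the concentration tested), three compounds have been measured:

Compound 1, `Nc1scc(CN2CCN(c3cccc(Cl)c3Cl)CC2)c1C(=O)c1ccc(Cl)cc1`: 3.2%
Compound 2, `COc1ccc(N2CCN(Cc3csc(N)c3C(=O)c3ccc(Cl)cc3)CC2)cc1`: 0%
Compound 3, `Nc1scc(CN2CCN(c3cccc(F)c3)CC2)c1C(=O)c1ccc(Cl)cc1`: -37%

Compound 3 stands lowest of the three; its nearest neighbour is compound 2, with a number 37 percentage points lower from compound 2 to compound 3 (beyond the scatter), and the furthest is compound 1, with a number 40.2 percentage points lower from compound 1 to compound 3 (beyond the scatter). Both steps are large, and both swap the whole aryl group on the ring nitrogen. Compound 4, `Nc1scc(CN2CCN(c3ccccc3F)CC2)c1C(=O)c1ccc(Cl)cc1`, differs from compound 3 only in 2-fluorophenyl in place of 3-fluorophenyl on an amine nitrogen in a ring. Going by the values given here, no measured step moves a fluorine within the same ring, so the two large steps only show that this position of the shared core is sensitive. Compound 4 is therefore expected to lie somewhere between compound 3 and the other two, with an estimated a number 22 percentage points higher from compound 3 to compound 4 (beyond the scatter). The estimate for compound 4 is -15%, ranging from -45% to 15%.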

Compound 4, a percentage reported as activity, at one concentration (the size of the read-out at that concentration, not a potency): -1%
The estimate for compound 4 lay 14 percentage points below the measured number; low and high end bracket the measured number.
By their numbers in this assay, from the lowest: compound 3; then compounds 4, 2 and 1 (each within the scatter of the next).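

In this assay, the two fluorophenyl groups have the same atoms, yet moving the fluorine alone gives a number 36 percentage points higher from compound 3 to compound 4 (beyond the scatter) on the shared core. So at this position, where a single fluorine sits on the aryl ring matters, not only which aryl group is present. The 2-fluorophenyl group cannot be separated from the two other aryl groups, with a number 1 percentage points lower from compound 2 to compound 4 (within the scatter) and a number 4.2 percentage points lower from compound 1 to compound 4 (within the scatter) in the comparison.

On these data alone, whether plain phenyl, with no fluorine at all, would stand with compound 3 or with the other three remains open. Nothing measured here explains why the position of the fluorine matters.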